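The source may hold more compounds than are shown below. What is called first, only, known or untested is meant among the compounds shown, and "the series" means these compounds.

Measured compounds, in an ADME assay on J774 cells (Mus musculus, strain BALB/c) for cytotoxicity, read by resazurin assay, with a stated time of 72 h; a lower number here means that less compound is tolerated, a higher number that more compound is tolerated:
compound 1 `CC(/C=N/Nc1ccc([N+](=O)[O-])cc1)=N\NC(=O)c1ccccc1Nc1ccccc1` gives > 100000 nM, a limit.
compound 2 `CC(/C=N/Nc1ccc([N+](=O)[O-])cc1)=N\NC(=O)c1ccc(N)cc1` gives 75000 nM.
compound 3 `CC(/C=N/Nc1ccc([N+](=O)[O-])cc1)=N\NC(=O)c1ccccc1F` gives > 100000 nM, a limit.

Compound 3 thus stands at a limit rather than at a number, and (the limit of > 100000 nM in this assay, at which 2 of the 3 values shown sit). Compound 4 `CC(/C=N/Nc1ccc([N+](=O)[O-])cc1)=N\NC(=O)c1cccc(C)c1` differs from compound 3 by 3-methylphenyl in place of 2-fluorophenyl on a carbonyl carbon. The change at the carbonyl carbon has one measured counterpart, an at least 1.3-fold higher number from compound 2 to compound 3 (0.12 log units; that floor lies within the scatter), whose floor lies within the scatter. The step that the two limits leave unreadable from compound 1 to compound 3 cannot be read at all. No step beyond the scatter is expected in this assay for this change. Compound 4 is expected to stay at the limit, a step that the limit leaves unreadable from compound 3 to compound 4. Compound 4 is estimated at 120000 nM, range 50000 nM to 300000 nM.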

Compound 4, half-maximal cytotoxic concentration: > 100000 nM
Compound 4: a limit, no number; the forecaster's own chance of this, stated with the estimate: 70%; the middle value is on the limit's open side.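

In this assay compound 4 also sits at a limit, so 3-methylphenyl on the carbonyl carbon leaves the same open reading as 2-fluorophenyl: the limit of > 100000 nM in this assay, at which 3 of the 4 values shown sit. Against 4-aminophenyl, the change gives an at least 1.3-fold higher number from compound 2 to compound 4 (0.12 log units; that floor lies within the scatter), a floor that does not settle the size of the step. The step between the two limits cannot be read.

From the compounds shown here alone, whether a carboxylic acid or a dimethylamino group in this place would give a number rather than a limit stays open. So does any ranking among compound 1, compound 3 and compound 4.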